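Ethoxy to cyclopropyloxy on compound 3

The source may report more compounds than this note shows. Statements on the series, on what has been measured and on what is new or still open speak of the compounds shown alone.

Of the compounds shown here, three that share one core have been measured in a functional assay on MCF7 cells (Homo sapiens) for antiproliferative activity, read by MTT assay, with a stated time of 48 h; on this read-out lower numbers stand for stronger inhibition and higher numbers for weaker inhibition. Compound 1 `CCOc1cc(-c2ccc3cc[nH]c3c2)cn2c(-c3cc(OC)c(OC)c(OC)c3)nnc12` gives 334 nM, compound 2 `CCOc1cc(-c2ccc3[nH]ccc3c2)cn2c(-c3cc(OC)c(OC)c(OC)c3)nnc12` gives 284 nM, and compound 3 `CCOc1cc(-c2ccc3c(ccn3C)c2)cn2c(-c3cc(OC)c(OC)c(OC)c3)nnc12` gives 140 nM, the lowest number of the three. Exchanging 1H-indol-6-yl for 1H-indol-5-yl produces a 1.2-fold lower number from compound 1 to compound 2 (0.07 log units; within the scatter). Placing methyl in place of hydrogen on an aromatic nitrogen then produces a 2.0-fold lower number from compound 2 to compound 3 (0.31 log units; beyond the scatter), and the two changes together amount to a 2.4-fold lower number from compound 1 to compound 3 (0.38 log units; beyond the scatter).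

Compound 4 `COc1cc(-c2nnc3c(OC4CC4)cc(-c4ccc5c(ccn5C)c4)cn23)cc(OC)c1OC` departs from compound 3 at a different place, with cyclopropyl in place of ethyl on an oxygen on an aromatic ring. Going by the values given here, none of the measured steps changes this group, so the data hold no direct precedent for the exchange. They bear on it only by showing how large steps have been in this small set. Even the largest of them, a 2.4-fold lower number from compound 1 to compound 3 (0.38 log units; beyond the scatter), is modest. On these data alone, on that basis, no step beyond the scatter is expected in this assay, and the direction remains open, with a slight lean towards a higher number. The expected step is a 1.2-fold higher number from compound 3 to compound 4 (0.08 log units; within the scatter). The estimate for compound 4 is 170 nM, with an expected range from 70 nM to 420 nM.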

Compound 4, half-maximal inhibitory concentration: 118 nM
For compound 4 the middle estimate is 1.4-fold (0.16 log units) above the measured one; the measured number falls inside the stated range.
By their numbers in this assay, from the lowest: compounds 4 and 3 (each within the scatter of the next); then compounds 2 and 1 (each within the scatter of the next).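

In this assay, the exchange of ethoxy for cyclopropyloxy gives a 1.2-fold lower number from compound 3 to compound 4 (0.07 log units; within the scatter), the only step shown at this oxygen on an aromatic ring, since compounds 1, 2 and 3 all carry ethyl there. It shows that, in the setting of compound 3, ethyl of 2 heavy atoms can give way to cyclopropyl of 3 heavy atoms, with its three-membered non-aromatic ring, without a step beyond the scatter, so the two groups cannot be told apart in this assay. No measurement shown here offers an explanation for this result.

On these data alone, this step is read with 1-methyl-1H-indol-5-yl on the shared core, and whether cyclopropyloxy would behave the same way with the 1H-indol-6-yl of compound 1 or the 1H-indol-5-yl of compound 2 remains open. Also open, as far as these compounds go, is how far this oxygen tolerates other groups, for example a longer chain such as n-butyl, or a chain ending in an amine such as 2-(dimethylamino)ethyl, and whether either would produce a step beyond the scatter.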